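The source may hold more compounds than are shown below. What is called first, only, known or untested is meant among the compounds shown, and "the series" means these compounds.

Compound 1 `CCOC(=O)/C=C(C)/C(F)=C/C=C(C)/C=C/C1=C(C)CCCC1(C)C`, compound 2 `CCOC(=O)/C=C(C)/C=C/C=C(C)/C=C(/F)c1c(C)cc(OC)c(C)c1C` and compound 3 `CCNC(=O)/C=C(C)/C=C/C=C(C)/C=C/c1c(C)cc(OC)c(C)c1C` have been run in a functional assay on the whole organism (strain Hart Swiss) with Mus musculus as the target, with stated times of 5 days and 2 weeks, at a dose of 40 mg/kg by the intraperitoneal route; on this read-out higher numbers stand for a stronger effect at the one dose given and lower numbers for a weaker effect. Compound 1 gives 67%, compound 3 gives 73.8% and compound 2 gives 26%, the lowest of the three numbers, standing below compound 1 and below compound 3 by more than the scatter. Compound 4 `CCOC(=O)/C=C(C)/C=C/C=C(C)/C=C(\F)c1c(C)cc(OC)c(C)c1C` is the next point. It keeps every atom and bond of compound 2: the two compounds have the same atoms and bonds and differ only in configuration as drawn: 1 of 4 stereo elements differ; a double bond is drawn E in compound 2 and Z in compound 4. Within the data shown here, no step between two measured compounds of the set shows what redrawing a double bond does, so the direction of this step is open, and a shift beyond the scatter either way is possible. Compound 4 is expected to give 40%, within 15% to 70%. The expected step from compound 2 to compound 4 is a number 14 percentage points higher from compound 2 to compound 4 (beyond the scatter).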

Compound 4, a percentage reported as activity, at one dose (the size of the read-out at that dose, not a potency): 40%
Compound 4: the middle estimate sits on the measured number at the digits printed; low and high end bracket the measured number.
By their numbers in this assay, from the lowest: compound 2; then compound 4; then compounds 1 and 3 (each within the scatter of the next).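

In this assay, among these compounds, redrawing one double bond from E to Z is read for the first time, and the number moves: a number 14 percentage points higher from compound 2 to compound 4 (beyond the scatter). The shift is tied to configuration alone, since no atom enters or leaves: the fact that compounds 2 and 4 differ only in the configuration as drawn

On these data alone, whether the same redrawing moves the number in the same direction with a carboxylic acid in place of the ethyl ester stays open. The compounds shown also leave open what this double bond does with hydrogen in place of the fluorine.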